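The compounds below may be only part of what the source reports. "The series", "measured", "known", "first", "only" and "open" are said of these compounds alone.

Compound 1 `COc1ccc(-c2cc3ccccc3nc2/C=C/C(=O)c2ccc(OC)cc2OC)cc1`: 3210 nM
Compound 2 `COc1ccc(-c2cc3ccccc3nc2/C=C/C(=O)c2ccccn2)cc1`: 740 nM

In a functional assay on MDA-MB-231 cells (Homo sapiens) for antiproliferative activity, read by XTT assay, with a stated time of 72 h (on this read-out lower numbers stand for stronger inhibition and higher numbers for weaker inhibition), compound 1 stands at the higher of the two numbers shown, and compound 2 at the lower. Within the data shown here, the only measured step, a 4.3-fold lower number from compound 1 to compound 2 (0.64 log units; beyond the scatter), is a modest one. Compound 3 `COc1ccc(-c2cc3ccccc3nc2/C=C/C(=O)c2ccsc2)cc1` differs from compound 1 in one place: thiophen-3-yl in place of 2,4-dimethoxyphenyl on a carbonyl carbon. Among the measured compounds shown here, that change resembles the one leading to compound 2, so a step in the same direction, toward a lower number in this assay, is expected, though its size is uncertain. For compound 3 the estimate is 1200 nM, ranging from 400 nM to 3600 nM, an expected step of a 2.7-fold lower number from compound 1 to compound 3 (0.43 log units; beyond the scatter).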

Compound 3, half-maximal inhibitory concentration: 1060 nM
The estimate for compound 3 lay 1.1-fold (0.05 log units) above the measured number, and the stated range covers the measured number.
By their numbers in this assay, from the lowest: compounds 2 and 3 (each within the scatter of the next); then compound 1.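

In this assay, a second replacement of the 2,4-dimethoxyphenyl on the carbonyl carbon also gives a lower number (a 3.0-fold lower number from compound 1 to compound 3 (0.48 log units; beyond the scatter)), so this result no longer rests on compound 2 alone. Thiophen-3-yl and pyridin-2-yl cannot be told apart here (a 1.4-fold higher number from compound 2 to compound 3 (0.16 log units; within the scatter)). Nothing measured here explains these results. On these data alone, whether an aromatic ring is needed on the carbonyl carbon remains open, as a cyclohexyl group or a simple methyl group would test this. Also open, as far as these compounds go, is how a phenyl group without methoxy groups would compare with compound 1.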